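Methoxy count on the benzylamine arm of the series

The source may hold more compounds than are shown below. What is called first, only, known or untested is meant among the compounds shown, and "the series" means these compounds.

The set shares the core of compound 1 `Nc1cc(N)c2nc(-c3ccccc3)c(Oc3ccc(Cl)c(Cl)c3)nc2c1`, which is linked to its outer ring through an oxygen. In a functional assay on UACC-257 cells (Homo sapiens) for inhibition, read by sulforhodamine B assay, with a stated time of 48 h (a higher number here means that more compound is tolerated, a lower number that less compound is tolerated), compound 1 gives only a limit, < 100000 nM, and not a number. Compound 2 `Nc1cc(N)c2nc(-c3ccccc3)c(NCc3ccc(Cl)c(Cl)c3)nc2c1` instead joins the outer ring through a nitrogen on a saturated chain carbon; in this assay compound 2 gives 43700 nM. Compound 3 `COc1ccc(CNc2nc3cc(N)cc(N)c3nc2-c2ccccc2)cc1OC` keeps that chain and in this assay gives 55000 nM, which sits at the upper end of the two numbers shown, yet the step of a 1.3-fold higher number from compound 2 to compound 3 (0.10 log units; within the scatter) lies within the scatter, so no order between compound 2 and compound 3 can be read.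

Compound 4 `COc1cc(CNc2nc3cc(N)cc(N)c3nc2-c2ccccc2)cc(OC)c1OC` is the next step from compound 3: methoxy in place of hydrogen on an aromatic carbon. Going by the values given here, the only measured step that bears on it is a 1.3-fold higher number from compound 2 to compound 3 (0.10 log units; within the scatter), which exchanged both ring substituents at once and still moved the number only within the scatter. A single added methoxy is a smaller change than that exchange, so no step beyond the scatter is expected, and the step of a 1.1-fold higher number from compound 3 to compound 4 (0.02 log units; within the scatter) is expected to be small. One caution: the limit of < 100000 nM in this assay, at which 1 of the 3 values shown sits, shows that numbers near the top of the range may come back as a limit only. For compound 4 in this assay the expected value is 58000 nM, with a range from 27000 nM to 120000 nM.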

Compound 4, concentration lethal to 50% of the cells: 27500 nM
The estimate for compound 4 lay 2.1-fold (0.32 log units) above the measured number, and the stated range covers the measured number.
By their numbers in this assay, from the lowest: compounds 4, 2 and 3 (each within the scatter of the next).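

In this assay, going by these compounds alone, the new result is a 2.0-fold lower number from compound 3 to compound 4 (0.30 log units; within the scatter), so a methoxy in place of hydrogen at this position, on an aromatic carbon ortho to a methoxy group and meta to a methoxy group, gives no step that can be read. The earlier step tested an exchange of both ring substituents, whereas this one adds a single methoxy to a ring that already carries two, and neither step leaves the scatter, so the listed compounds give no order among 2, 3 and 4. Compound 4 also returns a number and not a limit, so the added methoxy leaves it on the measured part of the range, while the one limit in the set stands as before: the limit of < 100000 nM in this assay, at which 1 of the 4 values shown sits.

Still open is whether a hydroxyl or an amine at this same ring position would give a step beyond the scatter, since methoxy is the only group shown entering there. Also open, from the compounds shown here alone, is whether a longer chain between the ring nitrogen and the outer ring would move the number in this assay at all.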